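Ethynyl in place of thiophen-2-yl on a nucleoside core

The compounds below may be only part of what the source reports. "The series", "measured", "known", "first", "only" and "open" are said of these compounds alone.

Compound 2 `Cc1nc(N)c2c(-c3cccs3)cn([C@@H]3O[C@H](CO)[C@@H](O)[C@H]3O)c2n1` was tested in a functional assay on HCT-116 cells (Homo sapiens), read by MTT assay, with a stated time of 72 h; a higher number here means a weaker inhibitor, a lower number a stronger inhibitor. In this assay compound 2 gives > 20000 nM, which is a limit of the assay and not a number. Compound 2 therefore stands at the bottom of the values shown, because of the limit of > 20000 nM in this assay, at which 1 of the 2 values shown sits. For comparison, compound 1 `C#Cc1cn([C@@H]2O[C@H](CO)[C@@H](O)[C@H]2O)c2ncnc(N(C)C)c12` gives 180 nM in this assay and carries the ethynyl group on a different core. Compound 3 `C#Cc1cn([C@@H]2O[C@H](CO)[C@@H](O)[C@H]2O)c2nc(C)nc(N)c12` has not yet been measured. It differs from compound 2 in one place: ethynyl in place of thiophen-2-yl on an aromatic carbon. Within the data shown here, no measured pair of this kind is known here, so the size of the step can only be guessed. Since compound 1 with ethynyl gives 180 nM, compound 3 is expected to gain activity, with the expected step of an at least 10-fold lower number from compound 2 to compound 3 (1.00 log units; beyond the scatter) reaching beyond the usual scatter. Compound 3 is estimated at 2000 nM, within the range 300 nM to 15000 nM.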

Compound 3, half-maximal inhibitory concentration: > 20000 nM
Compound 3 gave a limit, no number; the forecaster's own chance of this, stated with the estimate: 25%; middle value at least 10-fold (1.00 log units) away from the limit.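

In this assay compound 3 gives > 20000 nM, a limit of the assay and not a number, and compound 2 also sits at a limit, so no step can be read between compound 2 and compound 3: the limit of > 20000 nM in this assay, at which 2 of the 3 values shown sit.

The compounds shown leave open whether ethynyl in place of thiophen-2-yl changes activity on this shared core at all.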